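This account rests on a few compounds, and the source may have more. Where it says the series, first, only, none or still open, it means among the compounds named here.

Two compounds in this series share a fused core and differ only at one amide-type nitrogen in a ring. Compound 1 `CC(C)[C@@H]1CC[C@@H](C)C[C@@]12N(C)C(=O)[C@@H]1[C@H]3C(=O)NC(=O)[C@H]3ON12` carries a hydrogen there, and in a functional assay, read by spectrophotometry, with a stated time of 2 h, tested at 1 mg/mL (a higher number here means a stronger effect of the compound at the concentration tested, a lower number a weaker effect), compound 1 gives 35.6%. Compound 2 `CC(C)[C@@H]1CC[C@@H](C)C[C@@]12N(C)C(=O)[C@@H]1[C@H]3C(=O)N(C)C(=O)[C@H]3ON12` carries a methyl on that nitrogen instead, and in this assay compound 2 gives 47.7%. Among the two numbers measured, compound 2 stands highest, the change being a number 12.1 percentage points higher from compound 1 to compound 2 (beyond the scatter), a modest rise that lies beyond the scatter.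

Compound 3 `CC(C)[C@@H]1CC[C@@H](C)C[C@@]12N(C)C(=O)[C@@H]1[C@H]3C(=O)N(c4ccccc4)C(=O)[C@H]3ON12` continues along the same nitrogen: phenyl in place of methyl on an amide-type nitrogen in a ring. Among the compounds with values here, only one measured step bears on this change, the one from hydrogen to methyl, and that step was modest. Within the data shown here, a phenyl is a larger group than a methyl, and no measured pair shows what a ring in this place does, so the direction is uncertain. A change of roughly the size already seen, in either direction, or none beyond the scatter, is the reasonable expectation, which amounts to an estimated step of a number 2.3 percentage points higher from compound 2 to compound 3 (within the scatter). For compound 3 the expected value in this assay is 50%, with a range from 30% to 70%.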

Compound 3, a percentage reported as activity, at one concentration (the size of the read-out at that concentration, not a potency): 35.4%
For compound 3 the middle estimate is 14.6 percentage points above the measured one; the measured number falls inside the stated range.
By their numbers in this assay, from the lowest: compounds 3 and 1 (each within the scatter of the next); then compound 2.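

In this assay, putting phenyl in place of methyl on this nitrogen gives a number 12.3 percentage points lower from compound 2 to compound 3 (beyond the scatter), so the rise seen with methyl does not continue when a six-membered aromatic ring takes its place. Comparing phenyl directly with the original hydrogen gives a number 0.2 percentage points lower from compound 1 to compound 3 (within the scatter), so these two groups cannot be told apart in this assay, and methyl is the only one of the three that stands apart. The read-out therefore does not climb steadily from hydrogen through methyl to phenyl: compound 2 lies above both of the others, and compound 3 goes against any such steady rise.

As far as these compounds go, it remains open whether methyl marks a narrow high point or whether other groups on this nitrogen, such as an ethyl, a benzyl, a longer chain or a chain ending in a carboxylic acid, would match or pass compound 2. No measurement available here accounts for why the numbers fall in this pattern.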